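This account rests on a few compounds, and the source may have more. Where it says the series, first, only, none or still open, it means among the compounds named here.

Compound 1, `O=C(O)Cc1sc(C(c2ccc(F)cc2)c2ccc(F)cc2)nc1-c1ccnc(N2CCCC2)c1`: 230 nM
Compound 2, `O=C(O)Cc1sc(C2COc3ccccc3O2)nc1-c1ccc(Cl)cc1`: 500 nM

In an in vitro assay on HEK385-7 cells for displacement of a labelled ligand from prostaglandin D2 receptor 2 (Homo sapiens) (a lower number here means a stronger inhibitor, a higher number a weaker inhibitor), compound 1 holds the lowest of the two numbers shown; compound 2 sits at a higher number, and that gap lies beyond the scatter. Compound 3, `Cc1cc(-c2nc(C(c3ccc(F)cc3)c3ccc(F)cc3)sc2CC(=O)O)cnc1N`, has not yet been measured. It differs from compound 1 in a single place: 6-amino-5-methylpyridin-3-yl in place of 2-(pyrrolidin-1-yl)pyridin-4-yl on an aromatic carbon. For the measured compounds named here, no measured pair that makes this kind of change is available, so the guess rests on compound 1 alone. A modest move toward a higher number is expected, about at the edge of the scatter. The expected step is a 1.7-fold higher number from compound 1 to compound 3 (0.24 log units; within the scatter). Compound 3 is accordingly estimated at 400 nM, with a range from 100 nM to 1500 nM.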

Compound 3, half-maximal inhibitory concentration: 880 nM
The estimate for compound 3 lay 2.2-fold (0.34 log units) below the measured number; the range from low to high includes it.
By their numbers in this assay, from the lowest: compound 1; then compounds 2 and 3 (each within the scatter of the next).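

In this assay, for the compounds shown here, 6-amino-5-methylpyridin-3-yl in place of 2-(pyrrolidin-1-yl)pyridin-4-yl gives a 3.8-fold higher number from compound 1 to compound 3 (0.58 log units; beyond the scatter), the first reading of a change at this position, on the aromatic carbon next to the ring nitrogen. The position therefore responds to the group it carries, with the rest of compound 1 unchanged. No measurement shown here gives a reason for this step. The compounds shown leave open whether the amine, the methyl or the changed ring attachment carries the step. They also leave open how a 2-(piperidin-1-yl)pyridin-4-yl group would read here.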